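The source may report more compounds than this note shows. Statements on the series, on what has been measured and on what is new or still open speak of the compounds shown alone.

Working notes on the series. Compound 1 `COc1cc2nc(SCC(=O)Nc3ccc(C#N)cc3)nc(Nc3c(C)cc(/C=C/C#N)cc3C)c2cc1OC` and compound 2 `COc1cc2nc(SCC(=O)Nc3ccc(C(F)(F)F)cc3)nc(Nc3c(C)cc(/C=C/C#N)cc3C)c2cc1OC` share the core and differ only by trifluoromethyl in place of cyano on an aromatic carbon; compound 3 `COc1cc2nc([S+]([O-])CC(=O)Nc3cccc([N+](=O)[O-])c3)nc(Nc3c(Cl)cc(/C=C/C#N)cc3Cl)c2cc1OC` carries a 3-nitrophenyl on the amide-type nitrogen. In an ADME assay on MT4 cells (Homo sapiens) for cytotoxicity, read by MTT assay, with a stated time of 5 days (on this read-out higher numbers stand for lower toxicity in this test and lower numbers for higher toxicity in this test), compound 1 reaches only a limit of the assay, > 227000 nM. Compound 2 likewise stops at a limit, > 211000 nM. The step that the two limits leave unreadable from compound 1 to compound 2 is accordingly unreadable. Compound 3 too returns only a limit in this assay, >= 83200 nM (the limit of >= 83200 nM in this assay, at which 1 of the 3 values shown sits), so compound 3 cannot be placed against compound 1 or compound 2 beyond the fact that all three sit at limits, none of them a number.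

Compound 4 `COc1cc2nc([S+]([O-])CC(=O)Nc3c(C)cc(C)cc3C)nc(Nc3c(Cl)cc(/C=C/C#N)cc3Cl)c2cc1OC` differs from compound 3 by 2,4,6-trimethylphenyl in place of 3-nitrophenyl on an amide-type nitrogen. Among the measured compounds shown here, no measured step bears on this change, as the single one available has no readable size. Compound 4 is therefore expected to behave like the others, the step that the limit leaves unreadable from compound 3 to compound 4 expected to stay within the scatter, most probably as a further limit. The estimate for compound 4 is 100000 nM, with a range from 50000 nM to 250000 nM.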

Compound 4, half-maximal cytotoxic concentration: 8870 nM
Compound 4: middle estimate off by 11-fold (1.05 log units), on the high side, and the stated range ends above it.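

In this assay, among the compounds shown here, the change on the amide-type nitrogen gives the first readable step (an at least 9.3-fold lower number from compound 3 to compound 4 (0.97 log units; beyond the scatter)), so this position can move the read-out beyond the scatter, towards higher toxicity in this test. Compound 4 is the only compound shown that returns a number rather than a limit, which ties the 2,4,6-trimethylphenyl to the one clearly lower value among the four. The size of the step remains a minimum, since it starts from a limit of compound 3: the limit of >= 83200 nM in this assay, at which 1 of the 4 values shown sits.

From the compounds shown here alone, whether the step follows from the loss of the nitro group or from the gain of the methyl groups stays open, and a plain phenyl on the same amide-type nitrogen would separate the two. Going by these compounds, whether this change would give a step of similar size on the core of compound 1 also stays open.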